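The source may report more compounds than this note shows. Statements on the series, on what has been measured and on what is new or still open speak of the compounds shown alone.

Measured compounds in a functional assay on DU-145 cells (Homo sapiens) for inhibition, read by trypan blue exclusion, with a stated time of 96 h; on this read-out higher numbers stand for weaker inhibition of growth and lower numbers for stronger inhibition of growth:
compound 1 `Cc1ccc(S/C(=C/c2ccc(Br)cc2)C(=O)c2ccc(Cl)cc2)cc1`: 25000 nM
compound 2 `Cc1ccc(CS/C(=C/c2c[nH]c3ccc(Cl)cc23)C(=O)c2ccc(Cl)cc2)cc1`: 1000 nM
compound 3 `O=C(/C(=C\c1ccc(Br)cc1)Sc1ccc(Br)cc1)c1ccc(Cl)cc1`: 1000 nM

Compound 3 stands level with compound 2 at the digits given, the two together holding the lowest numbers of the three; compound 1 gives the highest number. Going by the values given here, the only single-change step in the set is a 25-fold lower number from compound 1 to compound 3 (1.40 log units; beyond the scatter).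

Compound 4 `Cc1ccc(CS/C(=C/c2ccc(Br)cc2)C(=O)c2ccc(Cl)cc2)cc1` has not yet been measured in this assay. Relative to compound 3 the change is 4-methylbenzyl in place of 4-bromophenyl on a sulfur. Among the compounds with values here, no measured step covers this exact change. The step of a 25-fold lower number from compound 1 to compound 3 (1.40 log units; beyond the scatter) bears on it indirectly: it shows that the group on the sulfur moves the number strongly, and that a methyl on that ring, as in compound 1, goes with a far higher number than a bromo. The same 4-methylbenzyl on sulfur is carried, with a further difference in a second place, by compound 2, which gives 1000 nM, so a 4-methylbenzyl on sulfur is not by itself tied to weak inhibition. On balance a rise in the number is expected for compound 4, a 5.0-fold higher number from compound 3 to compound 4 (0.70 log units; beyond the scatter). Compound 4 is therefore estimated at 5000 nM, with a range from 1000 nM to 25000 nM.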

Compound 4, concentration for 50% growth inhibition: 10000 nM
Beside the measured number, compound 4's estimate is 2.0-fold (0.30 log units) below it, within the range that was stated.
By their numbers in this assay, from the lowest: compounds 2 and 3 (each within the scatter of the next); then compound 4; then compound 1.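

In this assay, going by these compounds alone, a 10-fold higher number from compound 3 to compound 4 (1.00 log units; beyond the scatter) gives the first measured step at this sulfur with 4-methylbenzyl in place of 4-bromophenyl, and the 4-bromophenyl compound keeps the lower number. Set against the earlier methyl-to-bromo step, a 2.5-fold lower number from compound 1 to compound 4 (0.40 log units; beyond the scatter) shows that 4-methylbenzyl in place of 4-methylphenyl on the same sulfur also lowers the number, but this does not bring compound 4 level with compound 3. With 4-methylbenzyl held on the sulfur, a 10-fold higher number from compound 2 to compound 4 (1.00 log units; beyond the scatter) shows that the low number of compound 2 depends on 5-chloro-1H-indol-3-yl on the double-bonded chain carbon, so 4-methylbenzyl on the sulfur does not by itself give that number.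

The compounds shown leave open how 4-bromobenzyl on the sulfur would read, which would separate the bromo from the benzyl part of the step, and how an amine, a carboxylic acid or a longer chain on that sulfur would read. No measurement shown gives a cause for any of these steps.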